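This account rests on a few compounds, and the source may have more. Where it says the series, first, only, none or still open, it means among the compounds named here.

Compound 1 `Cc1ccc(-c2cnc(C(=O)CCCCCCc3ccccc3)o2)nc1`: 2.8 nM
Compound 2 `O=C(CCCCCCc1ccccc1)c1ncc(C(=O)N2CCSCC2)o1`: 10 nM

Both compounds were tested in an assay (Rattus norvegicus) for inhibition of Fatty-acid amide hydrolase 1 (Homo sapiens); a higher number here means a weaker inhibitor, a lower number a stronger inhibitor. Compound 1 gives 2.8 nM, while compound 2 gives 10 nM, the higher of the two numbers. For the measured compounds named here, the single measured step, a 3.6-fold higher number from compound 1 to compound 2 (0.55 log units; beyond the scatter), swaps an aromatic substituent for an amide on the shared core.

Compound 3 `O=C(CCCCCCc1ccccc1)c1ncc(I)o1` has not yet been measured. It differs from compound 2 in one place: iodo in place of (thiomorpholin-4-yl)carbonyl on an aromatic carbon. The large ring-bearing amide is thus pared down to a single halogen atom on the same aromatic carbon of the core.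

Going by the values given here, no measured step covers this exchange. Among the compounds with values here, the one step available, a 3.6-fold higher number from compound 1 to compound 2 (0.55 log units; beyond the scatter), shows only that the group on this carbon matters to a modest degree. Removing nearly all of it, leaving just iodo, is a larger change than that, so a modest weakening beyond the scatter is expected, with wide uncertainty in either direction. The estimate for compound 3 in this assay is 30 nM, ranging from 8 nM to 120 nM, which would mean an expected step of a 3.0-fold higher number from compound 2 to compound 3 (0.48 log units; beyond the scatter).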

Compound 3, inhibition constant: 3 nM
Compound 3: middle estimate off by 10-fold (1.00 log units), on the high side; measured number below the stated range.
By their numbers in this assay, from the lowest: compounds 1 and 3 (each within the scatter of the next); then compound 2.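

In this assay, the group on this aromatic carbon, next to the ring oxygen, does not need to be large: replacing (thiomorpholin-4-yl)carbonyl, with its ring and 8 heavy atoms, by a single iodine atom gives a 3.3-fold lower number from compound 2 to compound 3 (0.52 log units; beyond the scatter). The iodo group also matches the 5-methylpyridin-2-yl group, with a 1.1-fold higher number from compound 1 to compound 3 (0.03 log units; within the scatter), so among these three compounds a ring on this carbon is not needed to reach the low number of compound 1. Nothing available explains why these groups give these numbers, so the comparison stands as an observation only. Still open, as far as these compounds go, is whether iodine itself matters, or whether a smaller atom or group, such as hydrogen, chlorine or methyl, on the same carbon would give a similar number. The compounds shown also leave open how a carboxylic acid or an amine would behave at this position, and whether the result for iodo would hold with a shorter chain leading to the phenyl ring.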